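A few compounds are considered here, and "the series" means these few. Any claim that something is new, unique, unknown or untested is made for them only; others in the source may bear on it.

Of the compounds shown here, three sharing one core have so far been measured in a physicochemical assay for solubility, read by HPLC, with a stated time of 4 h, at pH 2; on this read-out lower numbers stand for lower solubility and higher numbers for higher solubility. Compound 1 `COCCOC(=O)c1cc(N)c(Nc2ccc(C#N)cc2)cc1Oc1c(C)cc(/C=C/C#N)cc1C` gives 1.64 ug/mL. Compound 2 `Cc1cc(/C=C/C#N)cc(C)c1Oc1cc(Nc2ccc(C#N)cc2)c(N)cc1C(=O)NN` gives 89.6 ug/mL, and compound 3 `COC(=O)c1cc(N)c(Nc2ccc(C#N)cc2)cc1Oc1c(C)cc(/C=C/C#N)cc1C` gives 21.8 ug/mL, which stands second highest of the three numbers, nearer to compound 2 than to compound 1. Every step among them lies beyond the scatter: a 55-fold higher number from compound 1 to compound 2 (1.74 log units; beyond the scatter), a 13-fold higher number from compound 1 to compound 3 (1.12 log units; beyond the scatter), and a 4.1-fold lower number from compound 2 to compound 3 (0.61 log units; beyond the scatter).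

Compound 4 `CNC(=O)c1cc(N)c(Nc2ccc(C#N)cc2)cc1Oc1c(C)cc(/C=C/C#N)cc1C` has not yet been measured in this assay. It differs from compound 3 in one place: methylamino in place of methoxy on a carbonyl carbon. The measured step that bears most directly on this change is the one at the same carbonyl carbon, which was modest, while the two steps starting from compound 1 were both large. A step in the upward direction, beyond the scatter but smaller than the large ones, is therefore expected. Compound 4 is expected to show a step of a 2.1-fold higher number from compound 3 to compound 4 (0.31 log units; beyond the scatter), with an estimated value of 45 ug/mL in a range from 14 ug/mL to 140 ug/mL.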

Compound 4, solubility: 44.7 ug/mL
Beside the measured number, compound 4's estimate is 1.0-fold (0.00 log units) above it; the measured number falls inside the stated range.
By their numbers in this assay, from the lowest: compound 1; then compound 3; then compounds 4 and 2 (each within the scatter of the next).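

With methylamino in place of methoxy on the carbonyl carbon, this assay gives a 2.1-fold higher number from compound 3 to compound 4 (0.31 log units; beyond the scatter), so this position responds to a change of the atom bound to the carbonyl carbon even when the group keeps the same count of heavy atoms. Compared with 2-methoxyethoxy at the same carbon, methylamino gives a 27-fold higher number from compound 1 to compound 4 (1.44 log units; beyond the scatter), which sets it clearly apart from that chain as well. The two groups bound through nitrogen cannot be told apart, with a 2.0-fold lower number from compound 2 to compound 4 (0.30 log units; within the scatter), so methyl in place of amino on the amide-type nitrogen leaves no resolved difference.

As far as these compounds go, whether a primary amide, a carboxylic acid or a dimethylamino group on this carbonyl carbon would stand with methylamino and aminoamino remains open. Nothing available here explains any of these steps.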